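The compounds below may be only part of what the source reports. "The series", "measured", "known", "first", "only" and "open" are said of these compounds alone.

In a functional assay on A549 cells (Homo sapiens) for antiproliferative activity, read by MTT assay, with a stated time of 72 h (a lower number here means a stronger inhibitor, a higher number a weaker inhibitor), compound 1 `CO[C@@H]1C/C=C(\C)C(=O)N(C)[C@@H](C(C)C)C(=O)N[C@H](Cc2ccccc2)C(=O)N[C@@H](C(C)C)C(=O)O[C@H](c2ccccc2)[C@H](C)/C=C/C=C/1C` gives only a limit, > 100 nM. Compound 2 `CO[C@@H]1C/C=C(\C)C(=O)N(C)[C@@H](C(C)C)C(=O)N[C@H](Cc2ccccc2)C(=O)N[C@@H](C(C)C)C(=O)O[C@H](c2ccccc2)C/C=C/C=C/1C`, carrying hydrogen in place of methyl on a saturated ring carbon, also reaches only a limit, > 100 nM. The step that the two limits leave unreadable from compound 1 to compound 2 cannot be read, because both values sit at the limit of > 100 nM in this assay, at which 2 of the 3 values shown sit. Compound 3 `CC[C@H](C)[C@H]1C(=O)N[C@H](Cc2ccccc2)C(=O)N[C@@H](C(C)(C)O)C(=O)O[C@H](c2ccccc2)[C@H](C)/C=C/C=C(\C)[C@H](OC)C[C@@H]2O[C@@]2(C)C(=O)N1C`, built on a different core, gives 14.3 nM. Compound 4 `CO[C@@H]1C/C=C(\C)C(=O)N(C)[C@@H](C(C)C)C(=O)N[C@H](Cc2ccc(O)cc2)C(=O)N[C@@H](C(C)C)C(=O)O[C@H](c2ccccc2)[C@H](C)/C=C/C=C/1C` differs from compound 1 by hydroxy in place of hydrogen on an aromatic carbon, a hydroxy in place of hydrogen on an aromatic carbon, para to a large group. Going by the values given here, no measured step shows how such a change acts, and compound 1 is known only as a limit, so the expected step that the limit leaves unreadable from compound 1 to compound 4 is set near zero. Compound 4 is therefore expected at 300 nM, within 100 nM to 3000 nM.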

Compound 4, half-maximal inhibitory concentration: 35.9 nM
The estimate for compound 4 lay 8.4-fold (0.92 log units) above the measured number; measured number below the stated range.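

Changing benzyl to 4-hydroxybenzyl gives an at least 2.7-fold lower number from compound 1 to compound 4 (0.44 log units; beyond the scatter) in this assay. This shows that the aromatic carbon para to a large group responds to a hydroxy, and compound 4 is the first compound shown on the core of compound 1 with a measured number and not a limit. The true size of the step stays unknown because compound 1 is known only as a limit: the limit of > 100 nM in this assay, at which 2 of the 4 values shown sit.

On these data alone, whether a methoxy, an amine or a fluorine at this place would give a similar number stays open.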